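The source may hold more compounds than are shown below. What is called first, only, known or untested is meant among the compounds shown, and "the series" means these compounds.

Of the compounds shown here, three built on one shared core have been measured in an ADME assay on cells (Hepatocyte, Rattus norvegicus, strain Wistar Han) for pharmacokinetics, read by LC-MS, tested at 0.5 uM; a higher number here means faster removal of the compound, a lower number slower removal. Compound 1, `CNC(=O)c1cc(C(=O)NCC[C@@H]2CNCCO2)cc2c1O[C@H](CF)[C@H]2c1ccccc1`, gives 1.28 mL/min in this assay. Compound 2, `CNC(=O)c1cc(C(=O)N[C@@H]2C[C@H]2CO)cc2c1O[C@H](CF)[C@H]2c1ccccc1`, gives 1.65 mL/min in this assay. For compound 3, `CNC(=O)c1cc(C(=O)NC2CC2)cc2c1O[C@H](CO)[C@H]2c1ccccc1`, this assay reports only a limit, < 0.8 mL/min, and not a number. Compound 2 thus stands within the usual scatter of compound 1, and no order between the two can be read from the numbers.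

The unmeasured compound 4, `CNC(=O)c1cc(C(=O)NCCC[C@H]2OC[C@H](N)CO2)cc2c1O[C@H](CF)[C@H]2c1ccccc1`, differs from compound 2 at a single place: a group of 10 heavy atoms (7 carbon, 1 nitrogen, 2 oxygen; one six-membered non-aromatic ring with 2 hetero atoms) in place of a group of 5 heavy atoms (4 carbon, 1 oxygen; one three-membered non-aromatic ring of carbon only), on an amide-type nitrogen. Within the data shown here, only one measured step bears on this change, a 1.3-fold higher number from compound 1 to compound 2 (0.11 log units; within the scatter), in which a group carrying a six-membered non-aromatic ring with 2 hetero atoms gave way to a group carrying a three-membered non-aromatic ring of carbon only on the amide-type nitrogen, and it stayed within the scatter. The change toward compound 4 runs the other way, bringing back a group with a six-membered non-aromatic ring with 2 hetero atoms, so no step beyond the scatter in this assay is expected. The value of compound 4 in this assay is therefore estimated at 1.3 mL/min, with a range from 0.7 mL/min to 2.6 mL/min. For compound 4 this means an expected step of a 1.3-fold lower number from compound 2 to compound 4 (0.10 log units; within the scatter).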

Compound 4, intrinsic clearance in a liver preparation (reported as CLH), per the amount of preparation that the assay uses in the Hepatocyte assay: 1.39 mL/min
Compound 4: middle estimate off by 1.1-fold (0.03 log units), on the low side; low and high end bracket the measured number.
By their numbers in the Hepatocyte assay, from the lowest: compounds 1, 4 and 2 (each within the scatter of the next). At a limit, below all of these: compound 3.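

At the amide-type nitrogen, the Hepatocyte assay adds two more steps that stay within the usual scatter (a 1.2-fold lower number from compound 2 to compound 4 (0.07 log units; within the scatter); a 1.1-fold higher number from compound 1 to compound 4 (0.04 log units; within the scatter)), so the group of 10 heavy atoms with its six-membered non-aromatic ring with 2 hetero atoms cannot be told apart from the groups of compound 1 and compound 2. This place therefore accepts a three-membered ring of carbon only and two different groups with six-membered rings without any readable change in this read-out, although the pattern rests on compound 1, compound 2 and compound 4 alone. In a physicochemical assay for solubility (a lower number here means a less soluble compound, a higher number a more soluble compound), compound 2 gives 114 ug/mL and compound 4 gives 174 ug/mL (a 1.5-fold higher number from compound 2 to compound 4 (0.18 log units; within the scatter)), so the same exchange also stays within the scatter there.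

Nothing shown gives a cause for any of these values. Still open, from the compounds shown here alone, is whether a carboxylic acid or a much longer carbon chain on the amide-type nitrogen would give a step beyond the scatter in the Hepatocyte assay or the physicochemical assay, and whether the amine on the ring of compound 4 contributes to its numbers at all.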